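The source may report more compounds than this note shows. Statements on the series, on what has been measured and on what is new or still open speak of the compounds shown alone.

Working notes on the series. Compound 1 `CCOc1cc(C(=O)Nc2nn[nH]n2)nc(-c2ccc(C)cc2)c1` gives 65% in a functional assay on the whole organism with Rattus norvegicus as the target, at a dose of 1 mg/kg by the oral route; a higher number here means a stronger effect of the compound at the dose given, a lower number a weaker effect. Compound 2 `Cc1ccc(-c2cc(C)cc(C(=O)Nc3nn[nH]n3)n2)cc1` gives 80% in this assay. Going by the values given here, the single change between these two, methyl in place of ethoxy on an aromatic carbon, yields a number 15 percentage points higher from compound 1 to compound 2 (beyond the scatter). Compound 2 thus holds the higher of the two numbers in hand, and its gap to compound 1 lies beyond the scatter.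

Compound 3 `CNc1ccc(-c2cc(C)cc(C(=O)Nc3nn[nH]n3)n2)cc1` is not yet measured. Relative to compound 2 the change is methylamino in place of methyl on an aromatic carbon, on an aromatic carbon of a six-membered aromatic ring of carbon only. Among the compounds with values here, no measured step bears directly on this change: the only step available, a number 15 percentage points higher from compound 1 to compound 2 (beyond the scatter), concerns another position and another pair of groups, so it gives neither size nor direction here. In this assay no step beyond the scatter is therefore expected for compound 3, which is written as a number 5 percentage points lower from compound 2 to compound 3 (within the scatter). Compound 3 is accordingly estimated at 75%, with a range from 50% to 95%.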

Compound 3, a percentage reported as inhibition, in the whole organism at one dose (the size of the read-out at that dose, not a potency): 89%
Compound 3: middle estimate off by 14 percentage points, on the low side; the measured number falls inside the stated range.
By their numbers in this assay, from the lowest: compound 1; then compounds 2 and 3 (each within the scatter of the next).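

In this assay, the change of methyl to methylamino on an aromatic carbon of a six-membered aromatic ring of carbon only, para to a large group, gives a number 9 percentage points higher from compound 2 to compound 3 (within the scatter), so compound 2 and compound 3 cannot be told apart at this dose. This position therefore accepts methylamino as well as methyl, and a group with a hydrogen-bond donor and acceptor stands here in place of one with neither without a step beyond the scatter. Nothing on hand gives a reason for this result.

On these data alone, whether a free amine, dimethylamino or a longer chain such as ethylamino would fit this position equally well remains open. Also open, as far as these compounds go, is whether methylamino would give a similar read-out with ethoxy at the other position of the shared core.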